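The source may hold more compounds than are shown below. What is called first, only, known or untested is meant among the compounds shown, and "the series" means these compounds.

Working notes on the series. In a functional assay on A549 cells (Homo sapiens) for antiproliferative activity, read by MTT assay, with a stated time of 48 h (on this read-out higher numbers stand for weaker inhibition and lower numbers for stronger inhibition), compound 1 `Cn1cc(-c2cnc3ccc(NCc4ccc(F)cc4)nc3c2)cn1` gives > 50000 nM as a limit of the assay, not a number. Compound 2 `Cn1cc(-c2cnc3ccc(NS(=O)(=O)c4ccc(C(F)(F)F)cc4)nc3c2)cn1` gives > 50000 nM in this assay as a limit as well, so it has no graded value. Together the two compounds show the limit of > 50000 nM in this assay, at which 2 of the 2 values shown sit, and offer no number from which to count a step.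

The next compound is compound 3 `Cn1cc(-c2cnc3ccc(NS(=O)(=O)c4cccs4)nc3c2)cn1`. The change from compound 2 is thiophen-2-yl in place of 4-(trifluoromethyl)phenyl on a sulfonyl sulfur and it puts thiophen-2-yl in place of 4-(trifluoromethyl)phenyl on a sulfonyl sulfur.

Among the measured compounds shown here, no step between measured compounds is available for scale. In this assay no shift beyond the scatter is therefore expected, and a weak result near the limit seems the likeliest outcome. Expected here is a number no higher from compound 2 to compound 3 (the limit leaves the size open) and nothing larger than the usual scatter. The estimate for compound 3 is 50000 nM with an expected range of 20000 nM to 100000 nM and a good chance that the assay again reports only a limit.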

Compound 3, half-maximal inhibitory concentration: 39500 nM
Beside the measured number, compound 3's estimate is 1.3-fold (0.10 log units) above it, and the stated range covers the measured number.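

In this assay the series now holds one graded number, that of compound 3, and the other values remain limits: the limit of > 50000 nM in this assay, at which 2 of the 3 values shown sit.

Thiophen-2-yl in place of 4-(trifluoromethyl)phenyl on a sulfonyl sulfur gives an at least 1.2-fold lower number from compound 2 to compound 3 (0.10 log units; that floor lies within the scatter), and (thiophen-2-yl)sulfonyl in place of 4-fluorobenzyl on a nitrogen on an aromatic ring gives an at least 1.2-fold lower number from compound 1 to compound 3 (0.10 log units; that floor lies within the scatter). Both steps are floors, so neither establishes a real gain, yet thiophen-2-yl is the only group on this sulfonyl sulfur, among those shown, that yields a measurable value rather than a limit.

On these data alone, how far the true values of compound 1 and compound 2 lie from that of compound 3 stays open. Also open, as far as these compounds go, is what other groups on the sulfonyl sulfur would give, such as a simple methyl, a furan-2-yl, or a phenyl carrying an amine or a carboxylic acid, and whether any of them would reach a number clearly beyond the scatter from compound 3.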